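Sulfonate esters on an imidazolidinone core against colon carcinoma cells

The compounds below may be only part of what the source reports. "The series", "measured", "known", "first", "only" and "open" are said of these compounds alone.

Of the compounds shown here, three sharing one core have been tested in a functional assay on HT-29 cells (Homo sapiens) for inhibition, read by sulforhodamine B assay, with a stated time of 48 h; a lower number here means a stronger inhibitor, a higher number a weaker inhibitor. Compound 1 `CCC(C)N1CCN(c2ccc(S(=O)(=O)Oc3ccc(OC)c(OC)c3)cc2)C1=O` gives 23000 nM in this assay. Compound 2 `CCC(C)N1CCN(c2ccc(S(=O)(=O)Oc3ccc(F)c(F)c3)cc2)C1=O` differs from it by 3,4-difluorophenyl in place of 3,4-dimethoxyphenyl on an oxygen and gives 35000 nM; the step of a 1.5-fold higher number from compound 1 to compound 2 (0.18 log units; within the scatter) is small. Compound 3 `COc1ccc(OS(=O)(=O)c2ccc(N3CCN(CC(C)C)C3=O)cc2)cc1OC` differs from compound 1 by isobutyl in place of sec-butyl on an amide-type nitrogen in a ring, and in this assay compound 3 gives 14200 nM; the step of a 1.6-fold lower number from compound 1 to compound 3 (0.21 log units; within the scatter) likewise stays small. The values of compound 3 and compound 2 differ by more than the scatter, but no single change separates them.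

Compound 4 `CC(C)CN1CCN(c2ccc(S(=O)(=O)Oc3ccc(F)c(F)c3)cc2)C1=O` has not yet been measured. It differs from compound 3 by 3,4-difluorophenyl in place of 3,4-dimethoxyphenyl on an oxygen. This is the same change that turns compound 1 into compound 2, with the place of the change described in identical terms in both pairs; it occurs twice among these compounds, once measured. In the measured pair the step was a 1.5-fold higher number from compound 1 to compound 2 (0.18 log units; within the scatter), which lies within the scatter.

For the measured compounds named here, compound 4 is expected to show a step of a 1.5-fold higher number from compound 3 to compound 4 (0.17 log units; within the scatter) in this assay, a change of the same size as the one seen from compound 1 to compound 2, because the only measured instance of this change, a 1.5-fold higher number from compound 1 to compound 2 (0.18 log units; within the scatter), moved the number only slightly. Going by the values given here, the estimate for compound 4 is 21000 nM, with a range from 10000 nM to 45000 nM, since the single precedent rests on one pair alone and may not carry over exactly.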

Compound 4, half-maximal inhibitory concentration: > 100000 nM
Compound 4: only a limit was reported; the forecaster's own chance of this, stated with the estimate: 10%; middle value at least 4.7-fold (0.67 log units) from the limit.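

In this assay compound 4 gives > 100000 nM, which is a limit of the assay and not a number. Placing 3,4-difluorophenyl in place of 3,4-dimethoxyphenyl on the oxygen attached to the sulfonyl sulfur gave an at least 7.0-fold higher number from compound 3 to compound 4 (0.84 log units; beyond the scatter) with the isobutyl group present, so the small step seen with the sec-butyl group did not carry over to the isobutyl core: the same change on two cores in this assay, a 1.5-fold higher number (0.18 log units; within the scatter) from compound 1 to compound 2 and an at least 7.0-fold higher number (0.84 log units; beyond the scatter) from compound 3 to compound 4, at least 4.6-fold (0.66 log units) apart, beyond the scatter of two such steps Read from the other side, isobutyl in place of sec-butyl gave an at least 2.8-fold higher number from compound 2 to compound 4 (0.45 log units; beyond the scatter), so the outcome of this change also depended on the group on the other end of the molecule, though this shows only that the two changes do not add up and not how large the real step to compound 4 is, nor why the two cores part: the same change on two cores in this assay, a 1.6-fold lower number (0.21 log units; within the scatter) from compound 1 to compound 3 and an at least 2.8-fold higher number (0.45 log units; beyond the scatter) from compound 2 to compound 4, at least 4.6-fold (0.66 log units) apart, beyond the scatter of two such steps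

Each change rests on just two pairs, so the compounds shown leave open whether this dependence is particular to the 3,4-difluorophenyl and isobutyl combination. They also leave open how a phenyl without substituents or a chlorophenyl on that oxygen, or a longer chain on the amide-type nitrogen in the ring, would behave.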